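A second methoxy on the aryl group of compound 3

The source may hold more compounds than are shown below. What is called first, only, known or untested is meant among the compounds shown, and "the series" means these compounds.

Three compounds share one core and differ only in the aromatic group attached to it. Compound 1 `CSc1nc(NCCCCNc2ccnc3cc(Cl)ccc23)c(C#N)c(-c2ccccc2)n1` gives 4400 nM in an ADME assay on L1210 cells (Mus musculus) for inhibition, read by cell counting; a higher number here means a weaker inhibitor, a lower number a stronger inhibitor. Compound 2 `CSc1nc(NCCCCNc2ccnc3cc(Cl)ccc23)c(C#N)c(-c2cccc([N+](=O)[O-])c2)n1` gives 2100 nM in this assay. Compound 3 `COc1ccc(-c2nc(SC)nc(NCCCCNc3ccnc4cc(Cl)ccc34)c2C#N)cc1` gives 3200 nM in this assay. On these three numbers compound 3 stands second highest, but its distance to compound 1 and its distance to compound 2 both lie within the scatter of repeated measurements, so no order among the three can be read from them.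

Compound 4 `COc1ccc(-c2nc(SC)nc(NCCCCNc3ccnc4cc(Cl)ccc34)c2C#N)cc1OC` differs from compound 3 in one place: methoxy in place of hydrogen on an aromatic carbon. Among the compounds with values here, the closest precedent is a 1.4-fold lower number from compound 1 to compound 3 (0.14 log units; within the scatter), the same kind of change, methoxy in place of hydrogen, which stayed within the scatter. Within the data shown here, the only step beyond the scatter is a 2.1-fold lower number from compound 1 to compound 2 (0.32 log units; beyond the scatter), which concerns a nitro group and is modest. Among the measured compounds shown here, nothing among the measured compounds suggests that a second methoxy should move the number far. For compound 4 no step beyond the scatter is expected, and the expected step is a 1.1-fold lower number from compound 3 to compound 4 (0.03 log units; within the scatter). Compound 4 is estimated at 3000 nM, with a range from 1400 nM to 6500 nM.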

Compound 4, half-maximal inhibitory concentration: 18000 nM
For compound 4 the middle estimate is 6.0-fold (0.78 log units) below the measured one, and the stated range ends below it.
By their numbers in this assay, from the lowest: compounds 2, 3 and 1 (each within the scatter of the next, the first and the last beyond it); then compound 4.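

In this assay, a methoxy added ortho to a methoxy group gives a 5.6-fold higher number from compound 3 to compound 4 (0.75 log units; beyond the scatter), whereas the earlier methoxy on the phenyl group gave a 1.4-fold lower number from compound 1 to compound 3 (0.14 log units; within the scatter), so the same replacement of hydrogen by methoxy does not bring a step of the same size at each place on this ring. The 3,4-dimethoxyphenyl group also sets compound 4 apart from the other two compounds it can be compared with directly, with a 4.1-fold higher number from compound 1 to compound 4 (0.61 log units; beyond the scatter) and an 8.6-fold higher number from compound 2 to compound 4 (0.93 log units; beyond the scatter), making compound 4 the weakest inhibitor of the four. No measurement shown here accounts for this rise, so its origin remains unknown.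

From the compounds shown here alone, it remains open whether a methoxy at this place would give a step of this size on a ring without the first methoxy, or whether the step needs both groups together. Going by these compounds, it is also open how a hydroxy group, a fluorine atom or an ethoxy group at the same place would compare with methoxy.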